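Aryl Variation on the Pyrazole Carboxylic Acid Series

The compounds below may be only part of what the source reports. "The series", "measured", "known", "first", "only" and "open" are said of these compounds alone.

Measured compounds:
compound 1 `Cc1ccc(-c2c(C)nn(-c3nc(-c4ccc(Cl)c(Cl)c4)c(SC(C)C)s3)c2C(=O)O)cc1`, 3800 nM
compound 2 `COc1ccc(-c2c(C)nn(-c3nc(-c4ccc(Cl)c(Cl)c4)c(SC(C)C)s3)c2C(=O)O)cc1`, 2100 nM
compound 3 `Cc1nn(-c2nc(-c3ccc(Cl)c(Cl)c3)c(SC(C)C)s2)c(C(=O)O)c1-c1cccc(C(F)(F)F)c1`, 22000 nM

In a functional assay on BJAB cells (Homo sapiens) for antiproliferative activity, with a stated time of 4 days (a lower number here means that less compound is needed, a higher number that more compound is needed for the effect), compound 2 gives the lowest of the three numbers, yet its gap to compound 1, a 1.8-fold lower number from compound 1 to compound 2 (0.26 log units; within the scatter), is within the scatter, so the two cannot be ordered. Compound 3 sits clearly apart: the steps of a 5.8-fold higher number from compound 1 to compound 3 (0.76 log units; beyond the scatter) and a 10-fold higher number from compound 2 to compound 3 (1.02 log units; beyond the scatter) are both beyond the scatter, and the second is large.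

Compound 4 `Cc1cc(-c2c(C)nn(-c3nc(-c4ccc(Cl)c(Cl)c4)c(SC(C)C)s3)c2C(=O)O)cc(C)n1` is not yet measured. It differs from compound 2 at the aryl group on the shared core: 2,6-dimethylpyridin-4-yl in place of 4-methoxyphenyl on an aromatic carbon. Going by the values given here, no measured step exchanges a carbon-only ring for a ring with a hetero atom, so the bearing steps are indirect. The step from compound 1 to compound 2 shows that a small change at this aryl group can leave the number within the scatter, while the steps to compound 3 show that a different substitution pattern can raise the number markedly. The step of a 2.1-fold higher number from compound 2 to compound 4 (0.33 log units; beyond the scatter) is therefore expected to be modest, most likely toward a higher number. Compound 4 is estimated at 4500 nM in this assay, with a range from 1500 nM to 14000 nM.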

Compound 4, half-maximal effective concentration: 580 nM
Compound 4: the middle estimate sits 7.8-fold (0.89 log units) above what was measured; the measured number lies below the stated range.
By their numbers in this assay, from the lowest: compound 4; then compounds 2 and 1 (each within the scatter of the next); then compound 3.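

In this assay, this aryl position on the shared core accepts a six-membered aromatic ring with a hetero atom: at an equal count of heavy atoms, 2,6-dimethylpyridin-4-yl in place of 4-methoxyphenyl gives a 3.6-fold lower number from compound 2 to compound 4 (0.56 log units; beyond the scatter), and in place of 4-methylphenyl it gives a 6.6-fold lower number from compound 1 to compound 4 (0.82 log units; beyond the scatter), so compound 4 has the lowest number of the set. Against the 3-(trifluoromethyl)phenyl group, the range at this position widens to a 38-fold lower number from compound 3 to compound 4 (1.58 log units; beyond the scatter), a large step. No available evidence accounts for these steps.

The compounds shown do not separate the contribution of the ring nitrogen from that of the two methyl groups, which plain pyridin-4-yl and a mono-methyl pyridine would address. Going by these compounds, an amine or a longer chain on the pyridine ring also remains open.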